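The source may report more compounds than this note shows. Statements on the series, on what has been measured and on what is new or still open speak of the compounds shown alone.

Of the compounds shown here, three sharing one core have been measured in a functional assay on NCI-H460 cells (Homo sapiens) for cytotoxicity, read by MTT assay, with a stated time of 48 h; on this read-out higher numbers stand for weaker inhibition and lower numbers for stronger inhibition. Compound 1 `C=C1C(=O)O[C@H]2CC3=C[C@H](C/C(C)=C/[C@@H](OC(=O)c4ccc(C(C)=O)cc4)[C@H]12)OC3=O`, carrying 4-acetylphenyl on a carbonyl carbon, gives 2200 nM. Compound 2 `C=C1C(=O)O[C@H]2CC3=C[C@H](C/C(C)=C/[C@@H](OC(=O)CCCCBr)[C@H]12)OC3=O` gives > 10000 nM, which is a limit of the assay and not a number. Compound 3 `C=C1C(=O)O[C@H]2CC3=C[C@H](C/C(C)=C/[C@@H](OC(=O)CCCCC)[C@H]12)OC3=O`, carrying pentyl instead, gives 5900 nM, the higher of the two actual numbers. Compound 4 `C=C1C(=O)O[C@H]2CC3=C[C@H](C/C(C)=C/[C@@H](OC(=O)CC4CCCCC4)[C@H]12)OC3=O` has cyclohexyl in place of butyl on a saturated chain carbon bound to a carbonyl carbon. The closest guide is the modest 2.7-fold higher number from compound 1 to compound 3 (0.43 log units; beyond the scatter), which shows that this side group can shift the number, and compound 1 keeps a ring there. A small move toward a lower number is therefore expected, estimated as a 1.4-fold lower number from compound 3 to compound 4 (0.15 log units; within the scatter). The expected value for compound 4 is 4200 nM, with an estimated range from 1900 nM to 9500 nM.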

Compound 4, half-maximal inhibitory concentration: 2000 nM
Compound 4: the middle estimate sits 2.1-fold (0.32 log units) above what was measured; the measured number falls inside the stated range.
By their numbers in this assay, from the lowest: compounds 4 and 1 (each within the scatter of the next); then compound 3. At a limit, above all of these: compound 2.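

In this assay, replacing the open pentyl chain with cyclohexylmethyl matters at this position: a 3.0-fold lower number from compound 3 to compound 4 (0.47 log units; beyond the scatter). An aromatic ring is not needed to reach this level, as the all-carbon ring of compound 4 and the 4-acetylphenyl group of compound 1 cannot be told apart: a 1.1-fold lower number from compound 1 to compound 4 (0.04 log units; within the scatter). an at least 5.0-fold lower number from compound 2 to compound 4 (0.69 log units; beyond the scatter) is only a floor, resting on a limit and not a number: the limit of > 10000 nM in this assay, at which 1 of the 4 values shown sits.

Compound 4 gains both a ring and extra carbon, so these two changes remain unseparated. Going by these compounds, whether a cyclohexyl ring carrying an amine or a carboxylic acid would hold this level also stays open.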